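Propargyl urea in place of a dimethylaminoethyl urea

The compounds below may be only part of what the source reports. "The series", "measured", "known", "first", "only" and "open" are said of these compounds alone.

Compound 2 `CN(C)CCN(C)C(=O)Nc1cc2c(Nc3ccc(F)c(Cl)c3)ncnc2cc1O[C@H]1CCOC1` gives 450 nM in a functional assay on A-431 cells (Homo sapiens) for antiproliferative activity, read by sulforhodamine B assay, with a stated time of 72 h (on this read-out lower numbers stand for stronger inhibition and higher numbers for weaker inhibition), the lowest of the three numbers, though compound 3 `CN1CCN(C(=O)Nc2cc3c(Nc4ccc(F)c(Cl)c4)ncnc3cc2O[C@H]2CCOC2)CC1` at 675 nM and compound 1 `CN(C)CCNC(=O)Nc1cc2c(Nc3ccc(F)c(Cl)c3)ncnc2cc1O[C@H]1CCOC1` at 806 nM both lie within the scatter of it. Compound 4 `C#CCNC(=O)Nc1cc2c(Nc3ccc(F)c(Cl)c3)ncnc2cc1O[C@H]1CCOC1` differs from compound 2 by propargylamino in place of (2-(dimethylamino)ethyl)(methyl)amino on a carbonyl carbon. The measured steps all vary the same urea substituent: a 1.8-fold lower number from compound 1 to compound 2 (0.25 log units; within the scatter), a 1.2-fold lower number from compound 1 to compound 3 (0.08 log units; within the scatter) and a 1.5-fold higher number from compound 2 to compound 3 (0.18 log units; within the scatter). Within the data shown here, none of them swaps an amine-bearing chain for one with a triple bond and no hydrogen-bond acceptor, so no step speaks to this change directly, and the insensitivity seen so far gives no ground to expect a step beyond the scatter in this assay. Compound 4 is therefore estimated at 650 nM, within 250 nM to 2000 nM, an expected step of a 1.4-fold higher number from compound 2 to compound 4 (0.16 log units; within the scatter).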

Compound 4, half-maximal inhibitory concentration: 3730 nM
Compound 4: middle estimate off by 5.7-fold (0.76 log units), on the low side; the whole stated range lies below it.
By their numbers in this assay, from the lowest: compounds 2, 3 and 1 (each within the scatter of the next); then compound 4.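

On this carbonyl carbon the three amine-bearing groups gave values within the scatter of one another, but in this assay propargylamino falls clearly behind each of them: an 8.3-fold higher number from compound 2 to compound 4 (0.92 log units; beyond the scatter), a 5.5-fold higher number from compound 3 to compound 4 (0.74 log units; beyond the scatter) and a 4.6-fold higher number from compound 1 to compound 4 (0.67 log units; beyond the scatter). Compound 1 carries the same amide hydrogen as compound 4, so that hydrogen alone does not separate the propargyl urea from the amine-bearing ureas. The compounds shown leave open whether a plain propyl chain, or a morpholine, would stay with the amine-bearing groups or fall with propargylamino. No measurement at hand accounts for the loss.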